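A few compounds are considered here, and "the series" means these few. Any claim that something is new, unique, unknown or untested is made for them only; others in the source may bear on it.

Of the compounds shown here, two of a shared core have been measured in a functional assay on the whole organism (Abdomen, strain Swiss albino) with Mus musculus as the target, with stated times of 10 min and 5 min, at a dose of 30 mg/kg by the oral route; a lower number here means a weaker effect, a higher number a stronger effect of the compound at the dose given. Compound 1 `CN1C(=O)C2ON=C(c3cn(-c4ccccc4)nc3-c3ccc(Br)cc3)C2C1=O` gives 40.4%. Compound 2 `O=C1C2ON=C(c3cn(-c4ccccc4)nc3-c3ccc(Cl)cc3)C2C(=O)N1c1ccccc1` gives 43.2%, the higher of the two numbers, yet its nearest neighbour, compound 1, lies only a small distance below it, within the usual scatter, so the two cannot be told apart. Compound 3 `CN1C(=O)C2ON=C(c3cn(-c4ccccc4)nc3-c3ccc(Cl)cc3)C2C1=O` has not yet been measured. It differs from compound 2 by methyl in place of phenyl on an amide-type nitrogen in a ring. Compound 1 already carries the same methyl on the same nitrogen, with a bromo group instead of a chloro group on its other ring, and its value sits close to that of compound 2. On that basis the expected step of a number 2.2 percentage points lower from compound 2 to compound 3 (within the scatter) is small, with no clear direction beyond the scatter. Compound 3 is therefore estimated at 41%, within a range from 30% to 52%.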

Compound 3, a percentage reported as activity, at one dose (the size of the read-out at that dose, not a potency): 23.2%
Estimate against measurement, compound 3: 17.8 percentage points above; measured number outside the range, below it.
By their numbers in this assay, from the lowest: compound 3; then compounds 1 and 2 (each within the scatter of the next).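

In this assay, the step of a number 20 percentage points lower from compound 2 to compound 3 (beyond the scatter) shows that the group on the amide-type nitrogen matters when the other ring carries chloro, since methyl in place of phenyl lowers the effect beyond the scatter. The step of a number 17.2 percentage points lower from compound 1 to compound 3 (beyond the scatter) shows that with methyl on that nitrogen the halogen matters too, so chloro in place of bromo on an aromatic carbon is not a neutral swap. Nothing available explains why either change lowers the effect.

As far as these compounds go, it remains open how an ethyl or a benzyl group on that nitrogen would fall relative to methyl and phenyl. A fluoro group on the aromatic carbon would test whether the drop from bromo to chloro continues along the halogens.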